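Swapping one oxygen substituent for formyl in compound 2

This account rests on a few compounds, and the source may have more. Where it says the series, first, only, none or still open, it means among the compounds named here.

In a functional assay on MCF7 cells (Homo sapiens) for cytotoxicity, read by sulforhodamine B assay (on this read-out lower numbers stand for stronger inhibition and higher numbers for weaker inhibition), compound 2 (`C=C1[C@@H](OC(C)=O)C[C@@H]2[C@](C)(CO[Si](C)(C)C(C)(C)C)[C@H](OC(C)=O)CC[C@@]2(C)[C@@H]1C[C@@H](Nc1ccc(F)cc1)C1=CCOC1=O`) gives 4340 nM. Compound 3 (`C=C1[C@@H](OC(C)=O)C[C@@H]2[C@](C)(CO[Si](C)(C)C(C)(C)C)[C@H](OC(C)=O)CC[C@@]2(C)[C@@H]1C[C@@H](Nc1cccc(F)c1)C1=CCOC1=O`) gives 3820 nM, which places it level with compound 2. Compound 1 (`C=C1[C@@H](OC(C)=O)C[C@@H]2[C@](C)(COC=O)[C@H](OC(C)=O)CC[C@@]2(C)[C@@H]1C[C@@H](Nc1ccc(O)cc1)C1=CCOC1=O`) stands apart with a clearly higher number, 18100 nM.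

Compound 4 (`C=C1[C@@H](OC(C)=O)C[C@@H]2[C@](C)(COC=O)[C@H](OC(C)=O)CC[C@@]2(C)[C@@H]1C[C@@H](Nc1ccc(F)cc1)C1=CCOC1=O`) differs from compound 2 in one place: a group of 2 heavy atoms (1 carbon, 1 oxygen; no ring) in place of a group of 7 heavy atoms (6 carbon, 1 silicon; no ring), on an oxygen on a saturated carbon. The entering group is formyl.

Among the compounds with values here, the only measured step, a 1.1-fold lower number from compound 2 to compound 3 (0.06 log units; within the scatter), concerns the amine nitrogen, so it says nothing direct about this oxygen. Within the data shown here, no measured pair isolates the new change. Compound 1 already carries formyl but also differs from compound 4 on the amine nitrogen, so the value of compound 1, 18100 nM, is only a weak hint toward higher numbers.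

In this assay, the expected change is modest and uncertain: a 2.1-fold higher number from compound 2 to compound 4 (0.32 log units; beyond the scatter). For compound 4 the estimated value is 9000 nM, with an expected range of 3500 nM to 22000 nM.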

Compound 4, half-maximal inhibitory concentration: 12400 nM
For compound 4 the middle estimate is 1.4-fold (0.14 log units) below the measured one, within the range that was stated.
By their numbers in this assay, from the lowest: compounds 3 and 2 (each within the scatter of the next); then compounds 4 and 1 (each within the scatter of the next).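

In this assay, putting formyl in place of the group of 7 heavy atoms on this oxygen gives a 2.9-fold higher number from compound 2 to compound 4 (0.46 log units; beyond the scatter) and so shows that the substituent here does move the number, though only modestly. With formyl in place, fluoro in place of hydroxy on the aromatic carbon gives a 1.5-fold lower number from compound 1 to compound 4 (0.16 log units; within the scatter) and leaves compound 1 and compound 4 level, so the aromatic swap shows no measurable effect in this setting. No measured data here explain why the oxygen change raises the number.

On these data alone, it stays open how other groups on this oxygen, such as a free hydroxy group or an acetyl group, would read. As far as these compounds go, it also stays open whether formyl gives a step of similar size alongside the 3-fluorophenyl group of compound 3.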